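This account rests on a few compounds, and the source may have more. Where it says the series, first, only, none or still open, it means among the compounds named here.

Measured in an ADME assay on microsomes from liver (Homo sapiens) for metabolic stability; on this read-out lower numbers stand for a shorter-lived compound and higher numbers for a longer-lived compound:

- compound 1 `COc1cc(OCc2csc(-c3ccc(C(F)(F)F)cc3)n2)c2cc(-c3cn4nc(OC)sc4n3)oc2c1`: > 2 h (a limit, not a number)
- compound 2 `COc1cc(OCc2cccc(-c3ccc(C(F)(F)F)cn3)c2)c2cc(-c3cn4nc(OC)sc4n3)oc2c1`: 0.733 h
- compound 3 `COc1cc(OCc2cccc(-c3ccc(OC)nc3)c2)c2cc(-c3cn4nc(OC)sc4n3)oc2c1`: 0.733 h

Going by the values given here, compound 2 stands level with compound 3, and these are the only two exact numbers so far. Compound 4 `COc1cc(OCc2cccc(-c3ccc(C#N)cn3)c2)c2cc(-c3cn4nc(OC)sc4n3)oc2c1` carries cyano in place of trifluoromethyl on an aromatic carbon of compound 2 (cyano in place of trifluoromethyl on an aromatic carbon). Among the compounds with values here, the one measured step at this group is no change at the digits printed from compound 2 to compound 3 (within the scatter), where 6-methoxypyridin-3-yl replaces 5-(trifluoromethyl)pyridin-2-yl. Within the data shown here, with that step as the only guide, no shift beyond the scatter is expected in this assay. The estimated step is a 1.1-fold higher number from compound 2 to compound 4 (0.04 log units; within the scatter). For compound 4 the expected half-life is 0.8 h, with an estimated range of 0.4 h to 1.6 h.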

Compound 4, half-life: 1.57 h
Compound 4: middle estimate off by 2.0-fold (0.29 log units), on the low side, within the range that was stated.
By their numbers in this assay, from the lowest: compounds 2 and 3 (each within the scatter of the next); then compound 4. At a limit, above all of these: compound 1.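

Cyano in place of trifluoromethyl moves the half-life in this assay, with a 2.1-fold higher number from compound 2 to compound 4 (0.33 log units; beyond the scatter), a modest step just beyond the scatter, whereas the earlier change gave no change at the digits printed from compound 2 to compound 3 (within the scatter). The 5-cyanopyridin-2-yl group in place of 6-methoxypyridin-3-yl gives a 2.1-fold higher number from compound 3 to compound 4 (0.33 log units; beyond the scatter), so this position can separate compounds in this assay. Nothing at hand gives a cause for these steps.

On these data alone, whether an amine or a carboxylic acid on the same aromatic carbon would move the half-life further stays open. As far as these compounds go, compound 1 gives > 2 h, which is a limit and not a number, so the size of any cyano step on that compound stays open too.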